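Moving from 2-chlorophenyl to 3-chlorophenyl on compound 1

A few compounds are considered here, and "the series" means these few. Any claim that something is new, unique, unknown or untested is made for them only; others in the source may bear on it.

Measured in a functional assay on MDA-MB-231 cells (Homo sapiens) for cytotoxicity, read by sulforhodamine B assay, with a stated time of 72 h; on this read-out higher numbers stand for weaker inhibition of growth and lower numbers for stronger inhibition of growth:
- compound 1 `O=C(Nc1cc(C(F)(F)F)cc(C(F)(F)F)c1)C1CCc2ccccc2N1C(=O)c1ccccc1Cl`: 5250 nM
- compound 2 `CCC(=O)N1c2ccccc2CCC1C(=O)Nc1ccccc1C(F)(F)F`: > 80000 nM (a limit, not a number)
- compound 3 `CCCCCCCCC(=O)N1c2ccccc2CCC1C(=O)Nc1ccccc1O`: 54300 nM

Compound 1 at 5250 nM holds the lower of the two actual numbers in this assay, and its gap to compound 3 lies beyond the scatter. Compound 2 reports only a limit, so it cannot be placed exactly on this scale.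

The next compound to be tested is compound 4 `O=C(Nc1cc(C(F)(F)F)cc(C(F)(F)F)c1)C1CCc2ccccc2N1C(=O)c1cccc(Cl)c1`. It differs from compound 1 by 3-chlorophenyl in place of 2-chlorophenyl on a carbonyl carbon. The two have the same atoms, joined differently.

Going by the values given here, compound 2 and compound 3 each differ from compound 1 in more than one place, so no measured pair gives the size of this step. The expectation therefore stays close to compound 1 at 5250 nM, with no step beyond the scatter in either direction in this assay. The expected change is a 1.1-fold lower number from compound 1 to compound 4 (0.02 log units; within the scatter). For compound 4 the estimated value is 5000 nM, with an expected range from 2000 nM to 13000 nM.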

Compound 4, concentration for 50% growth inhibition: 1190 nM
Compound 4: the middle estimate sits 4.2-fold (0.62 log units) above what was measured, outside the stated range (below it).
By their numbers in this assay, from the lowest: compound 4; then compound 1; then compound 3. At a limit, above all of these: compound 2.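

On the carbonyl carbon whose other neighbour is the amide-type nitrogen in a ring, 3-chlorophenyl in place of 2-chlorophenyl gives a 4.4-fold lower number from compound 1 to compound 4 (0.64 log units; beyond the scatter) in this assay. Going by these compounds alone, the two compounds have the same atoms, joined differently, so this is the first reading of where the chlorine sits on this group, something compound 2 and compound 3 could not give, as each differs from compound 1 in more than one place. No measured property at hand bears on why the placement of the chlorine changes the read-out.

Open, as far as these compounds go, is whether chlorine itself is needed on this phenyl ring, a question that a fluorine, a methoxy group or a nitrile in its place would address. Also open, from the compounds shown here alone, is whether the step keeps its size when the other amide of compound 1 and compound 4 carries a different group, such as a pyridine ring.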